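The source may report more compounds than this note shows. Statements on the series, on what has been measured and on what is new or still open speak of the compounds shown alone.

Values in a functional assay on HT-29 cells (Homo sapiens) for antiproliferative activity, read by sulforhodamine B assay, with a stated time of 48 h; a lower number here means a stronger inhibitor, a higher number a weaker inhibitor:
- compound 1 (`CCc1ccc(NS(=O)(=O)c2ccc(N3CCNC3=O)cc2)cc1`): 660 nM
- compound 2 (`O=C1NCCN1c1ccc(S(=O)(=O)Nc2cccc(Br)c2)cc1`): 77 nM
- compound 3 (`Cc1cccc(NS(=O)(=O)c2ccc(N3CCNC3=O)cc2)c1C`): 190 nM

Compound 3 holds the middle place among the three numbers. Against its two neighbours the steps are a 2.5-fold higher number from compound 2 to compound 3 (0.39 log units; beyond the scatter) and a 3.5-fold lower number from compound 1 to compound 3 (0.54 log units; beyond the scatter).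

The next compound, not yet measured, is compound 4 (`Cc1ccc(NS(=O)(=O)c2ccc(N3CCNC3=O)cc2)c(C)c1`), with 2,4-dimethylphenyl in place of 2,3-dimethylphenyl on a sulfonamide nitrogen.

Among the measured compounds shown here, all three measured steps change the group at this same place, so they are the only guide. The largest is an 8.6-fold lower number from compound 1 to compound 2 (0.93 log units; beyond the scatter), and all three are modest. None of them is a close model, since each exchanges one group for a differently substituted one, whereas compound 3 and compound 4 have the same atoms, joined differently. The one weak hint is that compound 1, which carries 4-ethylphenyl, gives the highest number at 660 nM. A single compound sets no pattern, so only a slight rise in this assay is expected, most likely not beyond the scatter.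

The expected change is a 1.3-fold higher number from compound 3 to compound 4 (0.12 log units; within the scatter).

For compound 4 the estimated value is 250 nM, with an expected range of 90 nM to 700 nM.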

Compound 4, half-maximal inhibitory concentration: 180 nM
Compound 4: middle estimate off by 1.4-fold (0.14 log units), on the high side; the measured number falls inside the stated range.
By their numbers in this assay, from the lowest: compound 2; then compounds 4 and 3 (each within the scatter of the next); then compound 1.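

In this assay, among the compounds shown here, the step to an isomer with the same atoms is small, a 1.1-fold lower number from compound 3 to compound 4 (0.02 log units; within the scatter), so this exchange of 2,3-dimethylphenyl for 2,4-dimethylphenyl on the sulfonamide nitrogen does not separate the two compounds, a kind of comparison the earlier compounds did not offer. Compound 4 also keeps clear gaps to the other two groups, a 2.3-fold higher number from compound 2 to compound 4 (0.37 log units; beyond the scatter) and a 3.7-fold lower number from compound 1 to compound 4 (0.56 log units; beyond the scatter), so a substituent numbered 4 in the group's name does not by itself go with a number like that of compound 1 at 660 nM, although this rests on compound 1 and compound 4 alone. Nothing measured here speaks to why the numbers at this position fall as they do.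

The compounds shown leave open whether the gap to compound 2 goes with bromine itself or with its placing in 3-bromophenyl, which 3-methylphenyl or 3-chlorophenyl would test. They also leave open how this position responds to anything other than alkyl or bromo substituents on the phenyl ring, such as an amine, a carboxylic acid or a methoxy group.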